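The source may hold more compounds than are shown below. What is called first, only, known or untested is meant among the compounds shown, and "the series" means these compounds.

Measured so far:
- compound 1, `CCCCCCOC(=O)Nc1ccc([Se]C#N)cc1`: 35900 nM
- compound 2, `CCOC(=O)Nc1ccc([Se]C#N)cc1`: 46900 nM

In an ADME assay on BEAS-2B cells (Homo sapiens) for cytotoxicity, read by MTT assay, with a stated time of 72 h (a lower number here means a stronger inhibitor of growth, a higher number a weaker inhibitor of growth), compound 2 gives the highest of the two numbers, with compound 1 as its nearest neighbour, a gap a 1.3-fold higher number from compound 1 to compound 2 (0.12 log units; within the scatter) that stays within the scatter.

Compound 3, `N#C[Se]c1ccc(NC(=O)Oc2ccccc2)cc1`, differs from compound 2 by phenyl in place of ethyl on an oxygen next to a carbonyl group. Among the measured compounds shown here, the only measured step, from compound 1 to compound 2, also alters this chain and moved a 1.3-fold higher number from compound 1 to compound 2 (0.12 log units; within the scatter), so there is no footing for a shift beyond the scatter in this assay.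

Compound 3 is therefore expected near 40000 nM, between 15000 nM and 100000 nM, a step of a 1.2-fold lower number from compound 2 to compound 3 (0.07 log units; within the scatter).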

Compound 3, concentration for total growth inhibition: 38200 nM
Compound 3: middle estimate off by 1.0-fold (0.02 log units), on the high side; measured number inside the range.
By their numbers in this assay, from the lowest: compounds 1, 3 and 2 (each within the scatter of the next).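

The earlier compounds shown here varied only a saturated chain, whereas here a phenyl ring replaces that chain on an oxygen next to a carbonyl group. In this assay this gives a 1.2-fold lower number from compound 2 to compound 3 (0.09 log units; within the scatter) and a 1.1-fold higher number from compound 1 to compound 3 (0.03 log units; within the scatter). Among these three compounds, neither the ethyl, the hexyl nor the phenyl group sets one apart, and nothing available explains this.

From the compounds shown here alone, whether an amine or a carboxylic acid on this oxygen would move the number beyond the scatter stays open. So does the effect of changes elsewhere in the shared core.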